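A few compounds are considered here, and "the series" means these few. Any claim that something is new, unique, unknown or untested is made for them only; others in the source may bear on it.

Measured so far in an ADME assay on HOS cells (Homo sapiens) for cytotoxicity; on this read-out higher numbers stand for weaker inhibition and lower numbers for stronger inhibition:

Compound 1, `O=C1c2c(ccc(O)c2O)CN1Cc1cccc(F)c1`, gives 8600 nM.
Compound 2, `O=C1c2c(ccc(O)c2O)CN1Cc1cc(F)cc(F)c1`, gives 17200 nM.
Compound 3, `O=C1c2c(ccc(O)c2O)CN1Cc1ccc(F)c(Cl)c1`, gives 6870 nM.

Compound 1 and compound 2 differ in one place: fluoro in place of hydrogen on an aromatic carbon. This change made a step of a 2.0-fold higher number from compound 1 to compound 2 (0.30 log units; within the scatter), so the two numbers cannot be told apart. Compound 3 carries a chloro group as well, and the difference between its core and that of compound 1 is not broken down here; its value lies close to that of compound 1, within the scatter, and farther from that of compound 2, beyond the scatter.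

Compound 4, `O=C1c2c(ccc(O)c2O)CN1Cc1cc(Cl)c(F)cc1F`, has not yet been measured in this assay. It differs from compound 3 in one place: fluoro in place of hydrogen on an aromatic carbon. This is the same kind of change as that from compound 1 to compound 2, but the surroundings differ. In compound 2 the entering fluoro is meta to a fluoro group and meta to a large group; in compound 4 it is ortho to a large group, meta to a fluoro group and para to a chloro group.

Among the compounds with values here, with only one such pair to go on, a similar step is expected for compound 4, roughly a 1.9-fold higher number from compound 3 to compound 4 (0.28 log units; within the scatter), resting on the step from compound 1 to compound 2 of a 2.0-fold higher number from compound 1 to compound 2 (0.30 log units; within the scatter). Compound 4 is therefore estimated at 13000 nM in this assay, most likely between 5500 nM and 32000 nM.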

Compound 4, half-maximal inhibitory concentration: 8380 nM
Beside the measured number, compound 4's estimate is 1.6-fold (0.19 log units) above it; the measured number falls inside the stated range.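

In this assay, fluoro in place of hydrogen on an aromatic carbon now gives a second step, a 1.2-fold higher number from compound 3 to compound 4 (0.09 log units; within the scatter), so the two occurrences of the change can be set side by side: the same change on two cores in this assay, a 2.0-fold higher number (0.30 log units; within the scatter) from compound 1 to compound 2 and a 1.2-fold higher number (0.09 log units; within the scatter) from compound 3 to compound 4, 1.6-fold (0.21 log units) apart, within the scatter of two such steps. The two steps cannot be told apart, and neither step separates its own pair of compounds, so the change carries from the core of compound 1 to that of compound 3 without any detectable difference. Within the data shown here, this does not show that the change is without consequence in general or that it would read the same way on further cores, since it rests on only two pairs, the entering fluoro has different surroundings in each, and a real difference smaller than the scatter could go unseen.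

As far as these compounds go, all four compounds carry only fluoro and chloro groups on the six-membered aromatic ring, so it remains open whether a methoxy group, an amine or a carboxylic acid there would give numbers in this assay close to those seen here. Also open, from the compounds shown here alone, is how the same change would read with a longer chain in place of the chloro group.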